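Iodo to methyl in the halogen series

The compounds below may be only part of what the source reports. "The series", "measured", "known", "first", "only" and "open" are said of these compounds alone.

In a functional assay on NCI-H460 cells (Homo sapiens) for cytotoxicity, read by sulforhodamine B assay, with a stated time of 3 days (a higher number here means a weaker inhibitor, a lower number a stronger inhibitor), compound 3 `OCc1cn(Cc2cccc(I)c2)c2ccccc12` gives 100 nM, the highest number of the three measured, against compound 1 `OCc1cn(Cc2cccc(F)c2)c2ccccc12` at 40 nM and compound 2 `OCc1cn(Cc2cccc(Br)c2)c2ccccc12` at 28 nM. Compound 4 `Cc1cccc(Cn2cc(CO)c3ccccc32)c1` has methyl in place of iodo on an aromatic carbon. Going by the values given here, no measured compound carries methyl there, so only the halogen swaps bear on this change. Of these, a 1.4-fold lower number from compound 1 to compound 2 (0.15 log units; within the scatter), while a 2.5-fold higher number from compound 1 to compound 3 (0.40 log units; beyond the scatter) and a 3.6-fold higher number from compound 2 to compound 3 (0.55 log units; beyond the scatter). Both compounds without iodo sit lower than compound 3, so a modest move to a lower number is expected, with wide uncertainty. The expected change is a 2.0-fold lower number from compound 3 to compound 4 (0.30 log units; within the scatter). The estimate for compound 4 is 50 nM, within a range of 18 nM to 130 nM.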

Compound 4, half-maximal inhibitory concentration: 31 nM
Beside the measured number, compound 4's estimate is 1.6-fold (0.21 log units) above it; the measured number falls inside the stated range.
By their numbers in this assay, from the lowest: compounds 2, 4 and 1 (each within the scatter of the next); then compound 3.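

At this position this assay shows a 3.2-fold lower number from compound 3 to compound 4 (0.51 log units; beyond the scatter) and places methyl, which is not a halogen, level with the bromo and fluoro compounds. Going by these compounds alone, the remaining steps are a 1.1-fold higher number from compound 2 to compound 4 (0.04 log units; within the scatter) and a 1.3-fold lower number from compound 1 to compound 4 (0.11 log units; within the scatter) and leave iodo as the only one of the four groups that stands apart. Nothing measured here gives a reason for the iodo result.

On these data alone, whether a methoxy group, an amine or a carboxylic acid at this place stays level with methyl, bromo and fluoro or moves as iodo does remains open. As far as these compounds go, a longer chain there is equally open.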